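This account rests on a few compounds, and the source may have more. Where it says the series, first, only, none or still open, it means among the compounds named here.

Among the measured compounds shown here, in a functional assay on MGC-803 cells (Homo sapiens) for cytotoxicity, read by MTT assay, with a stated time of 72 h (on this read-out higher numbers stand for weaker inhibition and lower numbers for stronger inhibition), compound 2 `COc1cc2ncnc(NNC(=S)NC(=O)c3ccccc3)c2cc1OC` gives 3050 nM, the lowest of the three numbers measured so far. Compound 3 `O=C(NC(=S)NNc1ncnc2ccccc12)c1ccc(F)cc1` gives 3600 nM, a number within the scatter of that of compound 2, so the two cannot be told apart. For the measured compounds named here, compound 1 `COc1cc2ncnc(NNC(=S)NC(=O)c3ccc(F)cc3)c2cc1OC` gives 8300 nM, and the step of a 2.7-fold lower number from compound 1 to compound 2 (0.43 log units; beyond the scatter) is the one measured step that concerns the carbon at which compound 4 `COc1cc2ncnc(NNC(=S)NC(=O)c3ccc(C)cc3)c2cc1OC` differs from compound 2. Between compound 2 and compound 4 the change is methyl in place of hydrogen on an aromatic carbon. Going by the values given here, the measured step shows that fluoro at this aromatic carbon went with a modestly higher number than hydrogen; no measured pair shows what methyl does at the same place, and the fluoro result cannot simply be carried over. For compound 4 in this assay a small step is therefore expected, most likely toward a somewhat higher number, of about a 1.5-fold higher number from compound 2 to compound 4 (0.17 log units; within the scatter). Compound 4 is estimated at 4500 nM in this assay, with a range from 1800 nM to 11000 nM.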

Compound 4, half-maximal inhibitory concentration: 19700 nM
Compound 4: middle estimate off by 4.4-fold (0.64 log units), on the low side, outside the stated range (above it).
By their numbers in this assay, from the lowest: compounds 2 and 3 (each within the scatter of the next); then compound 1; then compound 4.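

In this assay, methyl in place of hydrogen on this aromatic carbon gives a 6.5-fold higher number from compound 2 to compound 4 (0.81 log units; beyond the scatter), so the higher number seen with fluoro is not unique to fluoro: both groups tried here go with a higher number than hydrogen. The two groups are also distinct from each other, as methyl in place of fluoro gives a 2.4-fold higher number from compound 1 to compound 4 (0.38 log units; beyond the scatter), which puts hydrogen lowest, fluoro in the middle and methyl highest among compounds 1, 2 and 4. No measurement offered here explains why this order arises.

Three groups at one carbon cannot show whether a chloro group, a methoxy group, an amine or a carboxylic acid would also raise the number. Going by these compounds, it also remains open whether methyl would have the same effect on the core of compound 3.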